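Swapping Chloro for Bromo on a Hydrazone Series

The source may report more compounds than this note shows. Statements on the series, on what has been measured and on what is new or still open speak of the compounds shown alone.

Compound 1 `Nc1c(C(=O)NC2CCCC2)oc2nc(-c3ccccc3)cc(C(F)(F)F)c12` gives 85000 nM
Compound 2 `Nc1c(C(=O)N/N=C/c2ccccc2)oc2nc(-c3ccccc3)cc(C(F)(F)F)c12` gives 70000 nM
Compound 3 `Nc1c(C(=O)N/N=C/c2ccc(Cl)cc2)oc2nc(-c3ccccc3)cc(C(F)(F)F)c12` gives 81000 nM

These three compounds share one core and were all measured in an ADME assay on HEK293 cells (Homo sapiens) for antiproliferative activity, read by MTT assay; on this read-out lower numbers stand for stronger inhibition and higher numbers for weaker inhibition. Compound 3 sits alongside the other two: its number differs from that of compound 1 and from that of compound 2 only within the scatter of the assay, so no ordering among the three can be claimed. The changes made so far have moved the read-out very little. Replacing the five-membered ring with a benzylidene hydrazone gave a 1.2-fold lower number from compound 1 to compound 2 (0.08 log units; within the scatter), and adding a chloro gave a 1.2-fold higher number from compound 2 to compound 3 (0.06 log units; within the scatter).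

Compound 4 `Nc1c(C(=O)N/N=C/c2ccc(Br)cc2)oc2nc(-c3ccccc3)cc(C(F)(F)F)c12` has not yet been measured. It differs from compound 3 by bromo in place of chloro on an aromatic carbon. The step that bears most directly on this is the earlier halogen step, which stayed within the scatter, so no shift beyond the scatter is expected here either; the estimated step is a 1.0-fold lower number from compound 3 to compound 4 (0.01 log units; within the scatter). Compound 4 is therefore expected to give about 80000 nM, with a range from 45000 nM to 140000 nM.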

Compound 4, half-maximal inhibitory concentration: 64000 nM
The estimate for compound 4 lay 1.3-fold (0.10 log units) above the measured number; the range from low to high includes it.
By their numbers in this assay, from the lowest: compounds 4, 2, 3 and 1 (each within the scatter of the next).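

On the aromatic carbon para to a large group, the change from 4-chlorophenyl to 4-bromophenyl gives a 1.3-fold lower number from compound 3 to compound 4 (0.10 log units; within the scatter), so a swap of one halogen for another also leaves this assay within the scatter. Bromo in place of hydrogen gives a 1.1-fold lower number from compound 2 to compound 4 (0.04 log units; within the scatter), and the full bromo-bearing group in place of the five-membered ring on the amide-type nitrogen gives a 1.3-fold lower number from compound 1 to compound 4 (0.12 log units; within the scatter), so neither of these steps separates compound 4 from its neighbours either. No supporting data are available to explain these small steps.

At this position the compounds shown carry only hydrogen, chloro and bromo, so it remains open whether an amine or a carboxylic acid there would shift the number beyond the scatter. From the compounds shown here alone, the role of the phenyl and trifluoromethyl groups also remains open, as both are the same in all four compounds.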